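The compounds below may be only part of what the source reports. "The series", "measured", "known", "first", "only" and "open" are said of these compounds alone.

Measured in a functional assay on MCF7 cells (Homo sapiens) for inhibition, read by MTT assay, with a stated time of 24 h; a lower number here means a stronger inhibitor of growth, a higher number a weaker inhibitor of growth:
- Compound 1 `COc1cccc(C(=O)n2c(-c3cn(C)c4ccccc34)nc3ccccc32)c1`: 15700 nM
- Compound 2 `COc1ccc2c(c1)c(-c1nc3ccccc3n1C(=O)c1ccccc1OC)cn2C`: 23900 nM

Compound 2 gives 23900 nM in this assay, which is within the usual scatter of compound 1 at 15700 nM, so these two numbers cannot be ranked. Compound 3 `COc1cccc(C(=O)n2c(-c3cn(C)c4ccc(OC)cc34)nc3ccccc32)c1` has not yet been measured. It contains the same atoms as compound 2, joined differently: 3-methoxyphenyl in place of 2-methoxyphenyl on a carbonyl carbon. In words, 3-methoxyphenyl stands in place of 2-methoxyphenyl on a carbonyl carbon. Compound 1 also carries 3-methoxyphenyl on its carbonyl carbon, but it differs from compound 2 in more than this one place. No measured pair isolates this change, so its effect has not been shown directly. The closeness of the two measured compounds gives no reason to expect a large change or to favour a clear direction. The expected size of a 1.3-fold lower number from compound 2 to compound 3 (0.10 log units; within the scatter) is therefore no greater than the usual scatter. The estimated value for compound 3 is 19000 nM, with an expected range of 9000 nM to 40000 nM.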

Compound 3, concentration for 50% growth inhibition: 14600 nM
The estimate for compound 3 lay 1.3-fold (0.11 log units) above the measured number, and the stated range covers the measured number.
By their numbers in this assay, from the lowest: compounds 3, 1 and 2 (each within the scatter of the next).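

For the compounds shown here, compound 2 and compound 3 are the first measured pair to isolate 3-methoxyphenyl in place of 2-methoxyphenyl on a carbonyl carbon, and in this assay this swap gives a 1.6-fold lower number from compound 2 to compound 3 (0.21 log units; within the scatter) with the rest of the structure held the same, so the two placements of the methoxy group cannot be told apart here. Compound 3 also isolates a second change, methoxy in place of hydrogen on an aromatic carbon, which gives a 1.1-fold lower number from compound 1 to compound 3 (0.03 log units; within the scatter) and likewise leaves no difference that can be read from these numbers. No separate measurement bears on these two results.

The compounds shown leave open whether a different group on this carbonyl carbon, such as 4-methoxyphenyl or a phenyl ring carrying an amine or a carboxylic acid, would produce a step beyond the scatter. They also leave open whether a longer chain in place of the methyl of either methoxy group would do so, since every change shown so far keeps the numbers within the scatter of one another.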